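The compounds below may be only part of what the source reports. "The series", "measured", "known", "first", "only" and "open" are said of these compounds alone.

Two compounds from this series carry a measured value in a functional assay on the whole organism (uterus) with Rattus norvegicus as the target, tested at 10 uM; a higher number here means a weaker effect of the compound at the concentration tested, a lower number a stronger effect. Compound 1, `Oc1nc(NCC2CCCCC2)nc2ccc(Cl)cc12`, gives 86% in this assay. Compound 2, `Oc1nc(NCc2ccccc2)nc2ccc(Cl)cc12`, gives 94.8% in this assay. Within the data shown here, the single step between them, a number 8.8 percentage points higher from compound 1 to compound 2 (within the scatter), is the only measured step in the set, and it concerns phenyl in place of cyclohexyl on a saturated chain carbon bound to a nitrogen on an aromatic ring. Compound 2 thus stands with the higher of the two numbers, but the gap to compound 1 lies within the scatter, so the two compounds cannot be ordered.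

Compound 3, `Oc1nc(NCc2ccccc2)nc2ccc(Br)cc12`, has not been measured. It differs from compound 2 by bromo in place of chloro on an aromatic carbon, the change sitting on an aromatic carbon of a six-membered aromatic ring of carbon only, part of a fused system of two rings. Among the measured compounds shown here, no measured step touches a halogen at this place, so nothing in the data speaks to this exchange. For the measured compounds named here, the only guide is that the one measured step was within the scatter. Compound 3 is therefore expected to give 93% in this assay, between 82% and 100%. The expected step is a number 1.8 percentage points lower from compound 2 to compound 3 (within the scatter), that is, none beyond the scatter.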

Compound 3, a percentage reported as activity, at one concentration (the size of the read-out at that concentration, not a potency): 76.8%
The estimate for compound 3 lay 16.2 percentage points above the measured number; the whole stated range lies above it.
By their numbers in this assay, from the lowest: compounds 3, 1 and 2 (each within the scatter of the next, the first and the last beyond it).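

Among these compounds, the exchange of chloro for bromo on an aromatic carbon of the six-membered aromatic ring of carbon only, meta to a fused ring and para to a fused ring, gives the first step in this assay that goes beyond the scatter, with a number 18 percentage points lower from compound 2 to compound 3 (beyond the scatter) and a stronger effect at the concentration tested. The earlier step on the side chain, a number 8.8 percentage points higher from compound 1 to compound 2 (within the scatter), stayed within the scatter, so only now does a single change in these compounds separate two values, and it does so at this ring position rather than on the chain. The two halogens are alike in every count computed from the structures and differ only in the element, and no data in hand offer any explanation for the step.

On these data alone, it remains open whether bromo in place of chloro would give a similar step with cyclohexyl on the side chain, as bromo appears here only together with phenyl. Also open, as far as these compounds go, is how fluoro, iodo, methyl or methoxy on this same aromatic carbon would read in this assay, and so whether the step is particular to bromo.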